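Swapping Methoxy for Hydroxymethyl: Expected Cell Tolerance

The compounds below may be only part of what the source reports. "The series", "measured", "known", "first", "only" and "open" are said of these compounds alone.

Of the compounds shown here, three have been measured in an ADME assay on HEK293 cells (Homo sapiens) for cytotoxicity, with a stated time of 6 h; a lower number here means that less compound is tolerated, a higher number that more compound is tolerated. Compound 1 `CCCCNc1nc(N)nc2cc(OC)ccc12` carries a methoxy group on its aromatic ring. In this assay compound 1 gives > 18000 nM, which is a limit of the assay rather than a number. Compound 2 `CCCCNc1nc(N)nc2cc(CO)ccc12` arises from compound 1 by hydroxymethyl in place of methoxy on an aromatic carbon. In this assay compound 2 gives > 18000 nM, again a limit. The step that the two limits leave unreadable from compound 1 to compound 2 therefore cannot be read. Compound 3 `CCCCNc1nc(N)nc2ccc(OC)cc12` has the same atoms as compound 1 joined differently; the difference between the two cores is not broken down here. In this assay compound 3 gives > 18000 nM, also a limit. Compound 4 `CCCCNc1nc(N)nc2ccc(CO)cc12` is not yet measured and arises from compound 3 by the same change, (hydroxymethyl in place of methoxy on an aromatic carbon). Within the data shown here, every value so far sits at the limit of > 18000 nM in this assay, at which 3 of the 3 values shown sit, so no compound shows any sign of being tolerated less than the others. Compound 4 is expected to behave alike, with an expected step of a number no higher from compound 3 to compound 4 (the limit leaves the size open). The expected value for compound 4 is 18000 nM, most likely again reported only as a limit. This expectation rests on compound 3 giving > 18000 nM.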

Compound 4, half-maximal cytotoxic concentration: > 18000 nM
Compound 4 gave a limit, no number; the forecaster's own chance of this, stated with the estimate: 90%; the middle value sits exactly at the limit.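

Compound 4 gives > 18000 nM, which is a limit of the assay and not a number. The step from compound 3 to compound 4 therefore cannot be read. The compounds shown leave open how much of each one the cells tolerate, and whether hydroxymethyl in place of methoxy changes that tolerance at all.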